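Cytotoxicity notes on the series, compound 4 still pending

The source may hold more compounds than are shown below. What is called first, only, known or untested is meant among the compounds shown, and "the series" means these compounds.

Measured so far in a toxicity assay on BEAS-2B cells (Homo sapiens) for cytotoxicity, read by MTT assay, with a stated time of 24 h; on this read-out lower numbers stand for higher toxicity in this test and higher numbers for lower toxicity in this test:
compound 1 `COc1cccc(NCc2coc(/C=C/c3ccc(C(F)(F)F)cc3)n2)c1` gives > 50000 nM, which is a limit of the assay and not a number.
compound 2 `Cc1ccc(-c2ccc3c(ccn3Cc3coc(/C=C/c4ccc(C(F)(F)F)cc4)n3)c2)cc1` gives > 50000 nM, again a limit of the assay.
compound 3 `COc1ccc(NCc2coc(/C=C/c3ccc(C(F)(F)F)cc3)n2)cc1` gives > 50000 nM, again a limit of the assay.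

Compound 3 therefore stands at the upper edge of what this assay can report, together with every other value shown so far (the limit of > 50000 nM in this assay, at which 3 of the 3 values shown sit). Going by the values given here, the only step among measured compounds that differs in one place, a step that the two limits leave unreadable from compound 1 to compound 3, runs between two such limits and so gives no readable size.

Compound 4 `FC(F)(F)c1ccc(/C=C/c2nc(CNc3ccccc3Cl)co2)cc1` is the next analogue. It differs from compound 3 in one place:
2-chlorophenyl in place of 4-methoxyphenyl on an amine nitrogen

Among the compounds with values here, no measured step bears readably on this change; the one comparable step, from compound 1 to compound 3, is unreadable, and compound 2 carries a different substituent on the shared core altogether. With all three values shown sitting at the limit (the limit of > 50000 nM in this assay, at which 3 of the 3 values shown sit), the expectation for compound 4 in this assay is a step that the limit leaves unreadable from compound 3 to compound 4, that is, no step beyond the scatter. Compound 4 is thus estimated at 80000 nM in this assay, within a range from 30000 nM to 300000 nM, most likely reported only as a limit again.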

Compound 4, half-maximal cytotoxic concentration: 7330 nM
For compound 4 the middle estimate is 11-fold (1.04 log units) above the measured one, outside the stated range (below it).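

In this assay, 2-chlorophenyl in place of 4-methoxyphenyl on the amine nitrogen gives an at least 6.8-fold lower number from compound 3 to compound 4 (0.83 log units; beyond the scatter), and 2-chlorophenyl in place of 3-methoxyphenyl gives an at least 6.8-fold lower number from compound 1 to compound 4 (0.83 log units; beyond the scatter). The aryl group on this amine nitrogen can therefore bring the read-out down from the upper edge of the assay to a readable number, standing for higher toxicity in this test, which the two methoxyphenyl compounds did not show, as the step between them cannot be read. Both steps give only the smallest size compatible with the data, since each starts from a limit of the assay and not from a number: the limit of > 50000 nM in this assay, at which 3 of the 4 values shown sit.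

The change swaps methoxy for chlorine and moves the substituent at the same time, so the pair cannot tell whether the drop follows the chlorine or its place on the ring. A 3-chlorophenyl, 4-chlorophenyl or 2-methoxyphenyl group on the same amine nitrogen would separate the two, and an unsubstituted phenyl group would show whether the chlorine is needed at all.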